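Swapping the Aryl Group on a Sulfonamide Nitrogen

The compounds below may be only part of what the source reports. "The series", "measured", "known", "first", "only" and "open" are said of these compounds alone.

Of the compounds shown here, three sharing one core have been measured in a functional assay on cells (leukaemia cell line, Homo sapiens) for inhibition, read by sulforhodamine B assay, with a stated time of 48 h; a lower number here means a stronger inhibitor of growth, a higher number a weaker inhibitor of growth. Compound 1 `O=S(=O)(Nc1ccc(Cl)c(Cl)c1)c1ccc(-c2cnc(C3CC3)o2)cc1` gives 416 nM, the second highest of the three numbers. Compound 3 `COc1cc(NS(=O)(=O)c2ccc(-c3cnc(C4CC4)o3)cc2)ccc1F` gives 328 nM, and the step of a 1.3-fold lower number from compound 1 to compound 3 (0.10 log units; within the scatter) stays within the scatter. Compound 2 `O=S(=O)(Nc1cc(Cl)ccc1Cl)c1ccc(-c2cnc(C3CC3)o2)cc1` gives 1020 nM, so that a 2.5-fold higher number from compound 1 to compound 2 (0.39 log units; beyond the scatter) and a 3.1-fold lower number from compound 2 to compound 3 (0.49 log units; beyond the scatter) are both beyond the scatter.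

Compound 4 `Cc1cc(Cl)ccc1NS(=O)(=O)c1ccc(-c2cnc(C3CC3)o2)cc1` differs from compound 1 in one place: 4-chloro-2-methylphenyl in place of 3,4-dichlorophenyl on a sulfonamide nitrogen. The step that bears most on this change is a 2.5-fold higher number from compound 1 to compound 2 (0.39 log units; beyond the scatter), where a rearranged dichlorophenyl on the same nitrogen raised the number modestly. Compound 4 also carries its substituents at different positions from compound 1, and a modest rise in this assay is therefore expected, though the small size of the evidence leaves the direction uncertain.

The estimated value for compound 4 is 700 nM, with a range from 300 nM to 1800 nM, corresponding to an expected step of a 1.7-fold higher number from compound 1 to compound 4 (0.23 log units; within the scatter).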

Compound 4, concentration for 50% growth inhibition: 277 nM
The estimate for compound 4 lay 2.5-fold (0.40 log units) above the measured number, outside the stated range (below it).
By their numbers in this assay, from the lowest: compounds 4, 3 and 1 (each within the scatter of the next); then compound 2.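

In this assay, the step of a 1.5-fold lower number from compound 1 to compound 4 (0.18 log units; within the scatter) and the step of a 1.2-fold lower number from compound 3 to compound 4 (0.07 log units; within the scatter) place the 4-chloro-2-methylphenyl group level with both 3,4-dichlorophenyl and 4-fluoro-3-methoxyphenyl on the sulfonamide nitrogen. Compound 2 alone stands apart, with the step of a 3.7-fold lower number from compound 2 to compound 4 (0.57 log units; beyond the scatter) joining the two earlier steps from it that lie beyond the scatter, so among these compounds a rearranged substitution pattern does not in itself raise the number. Nothing available explains why the 2,5-dichlorophenyl group differs from the other three groups.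

The compounds shown leave open how this nitrogen would respond to an unsubstituted phenyl, a cyclohexyl group or a pyridine ring. They also leave open the effect of an amine or a carboxylic acid on the aryl ring.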